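Isobutyl for Isopropyl on a Compound at the Assay Limit

The source may hold more compounds than are shown below. What is called first, only, known or untested is meant among the compounds shown, and "the series" means these compounds.

Three compounds have been measured in a functional assay, read by spectrophotometry, with a stated time of 30 min; on this read-out higher numbers stand for weaker inhibition and lower numbers for stronger inhibition:

Compound 1 `CCOC(=O)[C@@H](NC(=O)/C=C/c1ccc(O)c(OC)c1)C(C)C` gives 59600 nM
Compound 2 `CCOC(=O)[C@H](C)NC(=O)/C=C/c1ccc(O)c(O)c1` gives 29700 nM
Compound 3 `CCOC(=O)[C@@H](NC(=O)/C=C/c1ccc(OC(C)=O)c(OC)c1)C(C)C` is reported only as the limit > 500000 nM

Compound 3 therefore stands apart from the other two: for it the assay gave no number, only (the limit of > 500000 nM in this assay, at which 1 of the 3 values shown sits). Among the measured compounds shown here, the one measured step that leads to it, an at least 8.3-fold higher number from compound 1 to compound 3 (0.92 log units; beyond the scatter), is the replacement of hydrogen by acetyl on an oxygen on an aromatic ring.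

Compound 4 `CCOC(=O)[C@H](CC(C)C)NC(=O)/C=C/c1ccc(OC(C)=O)c(OC)c1` is the next compound, not yet measured. It differs from compound 3 in isobutyl in place of isopropyl on a saturated chain carbon bound to an amide-type nitrogen and a carbonyl carbon. For the measured compounds named here, no measured step touches this saturated chain carbon; the only measured step, from compound 1 to compound 3, concerns the acetyl on the ring oxygen and carries no information about the chain. With compound 3 already at the limit, no step beyond the scatter is expected in this assay, and a further limit is the most likely report.

Compound 4 is therefore expected to give about 500000 nM, within 200000 nM to 1500000 nM. The step this estimate implies is a number no higher from compound 3 to compound 4 (the limit leaves the size open).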

Compound 4, half-maximal inhibitory concentration: > 500000 nM
Compound 4: no number, only a limit (the forecaster's own chance of this, stated with the estimate: 75%); the middle value sits exactly at the limit.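

Among the compounds shown here, compound 3 and compound 4 are both reported only as limits in this assay, so no step between them can be read. The compounds shown leave open whether isobutyl in place of isopropyl changes inhibition in a compound that gives a measured number.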